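This account rests on a few compounds, and the source may have more. Where it says the series, first, only, none or still open, it means among the compounds named here.

Compound 1 `O=C(Nc1ccccc1)Nc1nc(NC2CC2)cc(Sc2c[nH]c3ccccc23)n1` gives 17500 nM in a functional assay on PC-3 cells (Homo sapiens) for inhibition, with a stated time of 72 h; a higher number here means a weaker inhibitor, a lower number a stronger inhibitor. Compound 2 `O=C(Nc1ccccc1)Nc1nc(Sc2c[nH]c3ccccc23)cc(N2CCN(c3ccccn3)CC2)n1` carries the change 4-(pyridin-2-yl)piperazin-1-yl in place of cyclopropylamino on an aromatic carbon and gives 21600 nM in this assay, a step of a 1.2-fold higher number from compound 1 to compound 2 (0.09 log units; within the scatter). Compound 3 `Cc1cc(Cl)ccc1NC(=O)Nc1nc(NC2CC2)cc(Sc2c[nH]c3ccccc23)n1` differs from compound 1 by 4-chloro-2-methylphenyl in place of phenyl on an amide-type nitrogen; in this assay compound 3 gives 11100 nM, a step of a 1.6-fold lower number from compound 1 to compound 3 (0.20 log units; within the scatter). Compound 4 `Cc1cc(Cl)ccc1NC(=O)Nc1nc(Sc2c[nH]c3ccccc23)cc(N2CCN(c3ccccn3)CC2)n1` has not yet been measured; it differs from compound 3 by 4-(pyridin-2-yl)piperazin-1-yl in place of cyclopropylamino on an aromatic carbon. For the measured compounds named here, this is the same kind of change as the one from compound 1 to compound 2, though the surroundings differ: in compound 1 the place is meta to a (phenylcarbamoyl)amino group, whereas in compound 3 it is meta to a large group. Because the earlier step was a 1.2-fold higher number from compound 1 to compound 2 (0.09 log units; within the scatter), the step from compound 3 to compound 4 in this assay is expected to be a 1.2-fold higher number from compound 3 to compound 4 (0.09 log units; within the scatter). Compound 4 is therefore estimated at 13500 nM, between 6000 nM and 32000 nM.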

Compound 4, half-maximal inhibitory concentration: 19800 nM
Compound 4: the middle estimate sits 1.5-fold (0.17 log units) below what was measured, and the stated range covers the measured number.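

Putting 4-(pyridin-2-yl)piperazin-1-yl in place of cyclopropylamino gives a 1.8-fold higher number from compound 3 to compound 4 (0.25 log units; within the scatter) in this assay, which agrees with the earlier step: the same change on two cores in this assay, a 1.2-fold higher number (0.09 log units; within the scatter) from compound 1 to compound 2 and a 1.8-fold higher number (0.25 log units; within the scatter) from compound 3 to compound 4, 1.4-fold (0.16 log units) apart, within the scatter of two such steps

Likewise, 4-chloro-2-methylphenyl in place of phenyl gives a 1.1-fold lower number from compound 2 to compound 4 (0.04 log units; within the scatter), again in agreement: the same change on two cores in this assay, a 1.6-fold lower number (0.20 log units; within the scatter) from compound 1 to compound 3 and a 1.1-fold lower number (0.04 log units; within the scatter) from compound 2 to compound 4, 1.4-fold (0.16 log units) apart, within the scatter of two such steps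

For the compounds shown here, all of these steps lie within the scatter, so the agreement shows only that neither change had a readable effect on either core; it does not show that a step of real size would carry over from one core to another.

The compounds shown leave open whether other groups at these two places, such as a morpholine or a carboxylic acid, would move the number beyond the scatter. They also leave open what replacing the (1H-indol-3-yl)sulfanyl group, shared by all four compounds, would do.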